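A few compounds are considered here, and "the series" means these few. Any claim that something is new, unique, unknown or untested is made for them only; others in the source may bear on it.

Values in a functional assay on A-375 cells (Homo sapiens) for antiproliferative activity, read by CCK-8 assay, with a stated time of 72 h, tested at 8 uM; a lower number here means a weaker effect, a higher number a stronger effect of the compound at the concentration tested:
compound 1 `Nc1ccccc1NC(=O)c1ccc(CSC(=S)N2CCN(c3cccnc3)CC2)cc1`: 88.8%
compound 2 `Nc1ccccc1NC(=O)c1ccc(CSC(=S)N2CCN(c3ccc(F)cc3)CC2)cc1`: 76.3%
compound 3 `CC1CCCCN1C(=S)SCc1ccc(C(=O)Nc2ccccc2N)cc1`: 85.2%

Compound 3 stands second highest of the three numbers; its distance to compound 1 and to compound 2 both lie within the scatter, so no order among the three is established. Compound 4 `CN1CCN(C(=S)SCc2ccc(C(=O)Nc3ccccc3N)cc2)CC1` differs from compound 3 by 4-methylpiperazin-1-yl in place of 2-methylpiperidin-1-yl on a thiocarbonyl carbon. Within the data shown here, the only measured step, a number 12.5 percentage points lower from compound 1 to compound 2 (beyond the scatter), swaps a group on an amine nitrogen in a ring and bears only loosely on a change of the whole amine at the thiocarbonyl carbon. Compound 1 and compound 3 carry different amines there and their values sit within the scatter of each other, so no step beyond the scatter is expected for a number 3.2 percentage points lower from compound 3 to compound 4 (within the scatter). Compound 4 is estimated at 82%, expected between 68% and 92%.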

Compound 4, a percentage reported as inhibition, at one concentration (the size of the read-out at that concentration, not a potency): 91.6%
Estimate against measurement, compound 4: 9.6 percentage points below; measured number inside the range.
By their numbers in this assay, from the lowest: compounds 2, 3, 1 and 4 (each within the scatter of the next, the first and the last beyond it).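

In this assay, methyl on an amine nitrogen in a ring separates from 4-fluorophenyl, a number 15.3 percentage points higher from compound 2 to compound 4 (beyond the scatter), but not from pyridin-3-yl, a number 2.8 percentage points higher from compound 1 to compound 4 (within the scatter), so an aromatic ring at this place is not required to keep the read-out in the range of compound 1. On the thiocarbonyl carbon, 4-methylpiperazin-1-yl in place of 2-methylpiperidin-1-yl gives a number 6.4 percentage points higher from compound 3 to compound 4 (within the scatter), so this change of amine cannot be resolved. No available evidence bears on these differences.

As far as these compounds go, whether a longer chain or a carboxylic acid on that ring nitrogen would stay with methyl or fall towards 4-fluorophenyl remains open. A read-out at one concentration also leaves relative potency unresolved.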